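The compounds below may be only part of what the source reports. "The series", "measured", "known", "first", "only" and "open" are said of these compounds alone.

The shared core appears in compound 1 `Cc1cc(=O)n(-c2ccc(Br)cc2F)nc1C(=O)Nc1ccc(Oc2ncnc3ccsc23)cc1` and compound 2 `Cc1cc(=O)n(-c2ccc(Br)cc2F)nc1C(=O)Nc1ccc(Oc2ncnc3ccsc23)c(F)c1`. Within the data shown here, in a functional assay on A549 cells (Homo sapiens) for cytotoxicity, read by MTT assay, with a stated time of 72 h (a higher number here means a weaker inhibitor, a lower number a stronger inhibitor), compound 1 gives 7930 nM and compound 2 gives 2980 nM; the single measured step is a 2.7-fold lower number from compound 1 to compound 2 (0.43 log units; beyond the scatter). In this assay compound 3 `O=C(Nc1ccc(Oc2ncnc3ccsc23)c(F)c1)c1nn(-c2ccc(F)cc2)ccc1=O` gives 8230 nM, a number lying within the scatter of compound 1, whereas compound 2 gives a lower number, beyond the scatter. Compound 4 `Cc1ccc(-n2ccc(=O)c(C(=O)Nc3ccc(Oc4ncnc5ccsc45)c(F)c3)n2)cc1` differs from compound 3 by methyl in place of fluoro on an aromatic carbon. Among the measured compounds shown here, the one measured step concerns another place in the molecule and does not bear on this change, so no shift beyond the scatter is expected. Accordingly the expected step is a 1.0-fold lower number from compound 3 to compound 4 (0.01 log units; within the scatter). Compound 4 is therefore estimated at 8000 nM, with a likely range from 3000 nM to 22000 nM.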

Compound 4, half-maximal inhibitory concentration: 11600 nM
Compound 4: middle estimate off by 1.5-fold (0.16 log units), on the low side; measured number inside the range.
By their numbers in this assay, from the lowest: compound 2; then compounds 1, 3 and 4 (each within the scatter of the next).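

Exchanging 4-fluorophenyl for 4-methylphenyl gives a 1.4-fold higher number from compound 3 to compound 4 (0.15 log units; within the scatter) in this assay, so at this place, para to a large group, this read-out does not separate methyl from fluoro. Among these compounds, the earlier measured step lay elsewhere in the molecule, so only this pair speaks to this position. Nothing available offers an explanation for this result. Still open, going by these compounds, is whether another group at this place, such as an amine, a carboxylic acid or a longer chain, would shift the number beyond the scatter.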